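Carboxy in Place of Methoxy: What Compound 3 May Tolerate

A few compounds are considered here, and "the series" means these few. Any claim that something is new, unique, unknown or untested is made for them only; others in the source may bear on it.

For the measured compounds named here, in an ADME assay on MT2 cells (Homo sapiens) for cytotoxicity, read by XTT assay, with a stated time of 4 days (a higher number here means that more compound is tolerated, a lower number that less compound is tolerated), compound 2 `COc1ccc(CN2C(=O)/C(=C/c3cc(C)n(-c4ccc(O)c(C(=O)O)c4)c3C)SC2=S)cc1` gives 75300 nM, the only plain number obtained. Compound 1 `Cc1cc(/C=C2\SC(=S)N(c3ccccc3)C2=O)c(C)n1-c1ccc(O)c(C(=O)O)c1` is reported in this assay only as a limit, > 100000 nM (the limit of > 100000 nM in this assay, at which 1 of the 2 values shown sits). Compound 3 `Cc1cc(/C=C2\SC(=S)N(Cc3ccc(C(=O)O)cc3)C2=O)c(C)n1-c1ccc(O)c(C(=O)O)c1`, not yet measured, differs from compound 2 by carboxy in place of methoxy on an aromatic carbon. Going by the values given here, the single measured step, an at least 1.3-fold lower number from compound 1 to compound 2 (0.12 log units; that floor lies within the scatter), alters the group on the amide-type nitrogen in a ring and stays within the scatter. A movement of similar size, with no direction beyond the scatter, is therefore expected for compound 3 in this assay, a 1.2-fold higher number from compound 2 to compound 3 (0.08 log units; within the scatter). Compound 3 is estimated at 90000 nM, between 40000 nM and 200000 nM.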

Compound 3, half-maximal cytotoxic concentration: 105000 nM
Compound 3: middle estimate off by 1.2-fold (0.07 log units), on the low side; low and high end bracket the measured number.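

In this assay, the benzyl group on the ring nitrogen now carries a change at its own far end, on an aromatic carbon para to a large group, and carboxy in place of methoxy gives a 1.4-fold higher number from compound 2 to compound 3 (0.14 log units; within the scatter). A hydrogen-bond donor thus enters at this position with no change beyond the scatter. Compound 1 is reported only as a limit, so its step to compound 3 cannot be read: the limit of > 100000 nM in this assay, at which 1 of the 3 values shown sits.

Going by these compounds, it remains open whether an amine at this position would also stay within the scatter. On these data alone, whether carboxy would do so at the end of a longer chain is equally open.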